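The compounds below may be only part of what the source reports. "The series", "measured", "known", "first", "only" and "open" are said of these compounds alone.

Measured compounds in an assay on membranes from HEK293 cells for displacement of a labelled ligand from adenosine receptor A2b (Homo sapiens), read by scintillation counting, with a stated time of 30 min, tested at 1 uM; on this read-out lower numbers stand for less inhibition and higher numbers for more inhibition at the one concentration tested (going by the name of the read-out):
- Compound 1 `CC1=C(C(=O)OCC(C)C)C(c2ccco2)NC(=O)N1C` gives 4%.
- Compound 2 `CC1=C(C(=O)OC(C)(C)C)C(c2ccco2)NC(=O)N1C` gives 26%.
- Compound 3 `CC1=C(C(=O)OCc2ccccc2)C(c2ccco2)NC(=O)N1C` gives 41%.

Compound 3 stands highest of the three numbers; compound 2 is nearest, and compound 1 furthest, both beyond the scatter. Every measured step changed the group on the oxygen next to the carbonyl group: the step of a number 22 percentage points higher from compound 1 to compound 2 (beyond the scatter) was modest, the step of a number 37 percentage points higher from compound 1 to compound 3 (beyond the scatter) was large, and the step of a number 15 percentage points higher from compound 2 to compound 3 (beyond the scatter) was modest.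

Compound 4 `CC1=C(C(=O)OCc2ccccc2)C(c2ccoc2)NC(=O)N1C` keeps the benzyl ester of compound 3 and differs from it elsewhere, in the five-membered aromatic ring on the saturated ring carbon of the shared core: furan-3-yl in place of furan-2-yl on a saturated ring carbon. Among the compounds with values here, none of the measured steps touches this ring, so they give no direct guidance on how the ring's point of attachment matters. Since the two rings have the same atoms, joined differently, the expectation is for no step beyond the scatter in this assay, with the uncertainty reflected in a wide range. Compound 4 is therefore estimated at 38% (range 15% to 60%), a step expected to be a number 3 percentage points lower from compound 3 to compound 4 (within the scatter).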

Compound 4, a percentage reported as inhibition, at one concentration (the size of the read-out at that concentration, not a potency): 49%
Compound 4: middle estimate off by 11 percentage points, on the low side; the range from low to high includes it.
By their numbers in this assay, from the lowest: compound 1; then compound 2; then compounds 3 and 4 (each within the scatter of the next).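

In this assay, swapping the point of attachment of the five-membered aromatic ring, with furan-3-yl in place of furan-2-yl on a saturated ring carbon, gives a number 8 percentage points higher from compound 3 to compound 4 (within the scatter). Within the data shown here, all the earlier steps changed only the group on the oxygen next to the carbonyl group, so this is the first sight of what happens at the ring carbon, and it shows that the two furan attachments cannot be told apart here when the benzyl ester is kept. Among these compounds, the ester group therefore moved the number beyond the scatter in the earlier steps, whereas this change of attachment does not, though this rests on a single pair of compounds. Nothing available on these compounds offers an explanation for this result.

It remains open whether the two furans would also read alike with the isobutyl or tert-butyl ester in place of the benzyl ester, since the only pair shown carries the benzyl group. Also open, from the compounds shown here alone, is how a different ring on that saturated ring carbon, such as a thiophene, a phenyl or a pyridine, would read in this assay.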